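This account rests on a few compounds, and the source may have more. Where it says the series, first, only, none or still open, it means among the compounds named here.

Working notes on the series. Among the compounds with values here, in a functional assay on U-87MG ATCC cells for inhibition, with U-87 MG (Homo sapiens) as the target, read by MTT assay, with a stated time of 72 h (a higher number here means a weaker inhibitor, a lower number a stronger inhibitor), compound 3 (`COc1ccccc1-c1csc2cnc(Nc3ccc(C(=O)NC4CCNCC4)cc3)nc12`) gives 650 nM, the middle of the three numbers so far. Compound 1 (`COc1ccccc1-c1csc2cnc(Nc3ccc(C(=O)NC4CCNCC4)cc3C)nc12`) gives the lowest number, 250 nM, and compound 2 (`COc1ccccc1-c1csc2cnc(Nc3cc(F)c(C(=O)NC4CCNCC4)cc3F)nc12`) gives the highest, 1480 nM. Compound 4 (`COc1ccccc1-c1csc2cnc(Nc3ccc(C(=O)NC4CCNCC4)cc3F)nc12`) is not yet measured. It differs from compound 3 by fluoro in place of hydrogen on an aromatic carbon, ortho to a large group and meta to a (piperidin-4-yl)carbamoyl group: fluoro in place of hydrogen on an aromatic carbon.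

Within the data shown here, the only measured step that changes one place is a 2.6-fold higher number from compound 1 to compound 3 (0.41 log units; beyond the scatter), hydrogen in place of methyl on an aromatic carbon. This step is modest and beyond the scatter. It involves the same carbon but concerns methyl, so it bears on the change only indirectly. Among the measured compounds shown here, no measured step isolates a fluoro group. Compound 2 also carries fluoro, and it gives 1480 nM, but it differs from compound 3 in more than one place. These two indications point in opposite directions, so no clear direction is expected in this assay. The expected change, estimated as a 1.1-fold higher number from compound 3 to compound 4 (0.03 log units; within the scatter), should stay within the scatter. The estimated value for compound 4 is 700 nM, with an expected range of 320 nM to 1500 nM.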

Compound 4, half-maximal inhibitory concentration: 2370 nM
Estimate against measurement, compound 4: 3.4-fold (0.53 log units) below; the measured number lies above the stated range.
By their numbers in this assay, from the lowest: compound 1; then compound 3; then compounds 2 and 4 (each within the scatter of the next).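

In this assay, within the data shown here, this aromatic carbon, ortho to a large group, proves sensitive to fluoro: a 3.6-fold higher number from compound 3 to compound 4 (0.56 log units; beyond the scatter) shows a real change where the earlier compounds offered only an indirect reading, and it runs in the same direction as a 2.6-fold higher number from compound 1 to compound 3 (0.41 log units; beyond the scatter), so that the three groups at this carbon order as methyl, hydrogen, fluoro from lowest number to highest, with a 9.5-fold higher number from compound 1 to compound 4 (0.98 log units; beyond the scatter) spanning the whole range. The further fluoro that sets compound 2 apart adds no separable change, since a 1.6-fold higher number from compound 2 to compound 4 (0.20 log units; within the scatter) stays within the scatter, which suggests that the fluoro at the carbon ortho to a large group is enough to reach this level and that the second one gives no measurable gain or loss. Nothing available explains why fluoro raises the number at this carbon or why methyl lowers it.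

On these data alone, three groups at a single carbon give an order but not a trend, so it remains open where a chloro, an ethyl or an amino group would fall relative to methyl and fluoro. Also open, as far as these compounds go, is whether the same order would hold on the other carbons of this ring, where only the further fluoro of compound 2 gives any reading.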